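The source may hold more compounds than are shown below. What is called first, only, known or untested is meant among the compounds shown, and "the series" means these compounds.

Compound 1 `CCCn1cnc2c(NC(=N)N)nc(N)nc21` gives 36500 nM
Compound 2 `CC(C)n1cnc2c(NC(=N)N)nc(N)nc21` gives 97200 nM
Compound 3 `CCn1cnc2c(NC(=N)N)nc(N)nc21` gives 54300 nM

These values come from a functional assay on MCF7 cells (Homo sapiens) for inhibition, read by fluorescence, with a stated time of 72 h; a lower number here means a stronger inhibitor, a higher number a weaker inhibitor. Compound 3 lies within the scatter of both others, with a 1.8-fold lower number from compound 2 to compound 3 (0.25 log units; within the scatter) and a 1.5-fold higher number from compound 1 to compound 3 (0.17 log units; within the scatter). Only a 2.7-fold higher number from compound 1 to compound 2 (0.43 log units; beyond the scatter) goes beyond it. Compound 4 `N=C(N)Nc1nc(N)nc2c1ncn2CCO` differs from compound 3 by hydroxy in place of hydrogen on a saturated chain carbon, two bonds along the chain from an aromatic nitrogen. For the measured compounds named here, no measured compound carries hydroxy there, so the evidence is indirect. The nearest guide is the change at that carbon from compound 1 to compound 3, which stayed within the scatter. A small step towards a higher number is therefore expected, namely a 1.2-fold higher number from compound 3 to compound 4 (0.08 log units; within the scatter). For compound 4 the estimated value is 65000 nM, with an expected range from 25000 nM to 170000 nM.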

Compound 4, half-maximal inhibitory concentration: > 100000 nM
Compound 4 gave a limit, no number (the forecaster's own chance of this, stated with the estimate: 20%); middle value at least 1.5-fold (0.18 log units) away from the limit.
By their numbers in this assay, from the lowest: compounds 1, 3 and 2 (each within the scatter of the next, the first and the last beyond it). At a limit, above all of these: compound 4.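

In this assay compound 4 gives a limit and no number: the limit of > 100000 nM in this assay, at which 1 of the 4 values shown sits. At this carbon, hydroxy in place of hydrogen gives an at least 1.8-fold higher number from compound 3 to compound 4 (0.26 log units; that floor lies within the scatter), and the comparison with the isopropyl compound gives an at least 1.0-fold higher number from compound 2 to compound 4 (0.01 log units; that floor lies within the scatter), so neither floor clears the scatter. For the compounds shown here, only an at least 2.7-fold higher number from compound 1 to compound 4 (0.43 log units; beyond the scatter) does so, and it is the first change to show a clear move towards a weaker inhibitor at this carbon.

As far as these compounds go, how far beyond its limit compound 4 lies remains open. So does whether an amine or a carboxylic acid in place of the hydroxy would behave the same way.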